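Four-Membered Ring in Place of a Five-Membered One

This account rests on a few compounds, and the source may have more. Where it says the series, first, only, none or still open, it means among the compounds named here.

Going by the values given here, compound 2 `c1ccc2c(c1)CC(CCCN1CCN(c3cccc4c3OCCO4)CC1)C2` gives the only number among the three measured compounds in an assay for activation of Adrenergic receptor alpha-1 (Rattus norvegicus) (a higher number here means that more compound is needed for the effect, a lower number that less compound is needed), namely 1.73 mg/kg. Compound 1 `C1=C(CCN2CCN(c3cccc4c3OCCO4)CC2)c2ccccc2CCC1` reaches only a limit, > 2.5 mg/kg. Compound 3 `Fc1cccc2c1CC2CN1CCN(c2cccc3c2OCCO3)CC1` likewise stops at a limit, > 1.25 mg/kg. Among the compounds with values here, no step between measured compounds that differ in one place is available, so compound 2 stands alone as a reference. Compound 4 `c1ccc2c(c1)CC2CCCN1CCN(c2cccc3c2OCCO3)CC1` differs from compound 2 by a group of 8 heavy atoms (8 carbon; one four-membered non-aromatic ring of carbon only, one six-membered aromatic ring of carbon only) in place of a group of 9 heavy atoms (9 carbon; one five-membered non-aromatic ring of carbon only, one six-membered aromatic ring of carbon only), on a saturated chain carbon, three bonds along the chain from an amine nitrogen in a ring. The aromatic ring and the chain are kept, and a five-membered non-aromatic ring gives way to a four-membered one. In this assay the step is expected to stay within the usual scatter: a 1.2-fold higher number from compound 2 to compound 4 (0.06 log units; within the scatter). Compound 4 is therefore estimated at 2 mg/kg, between 0.9 mg/kg and 4.5 mg/kg.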

Compound 4, dose for half-maximal effect: 0.45 mg/kg
Estimate against measurement, compound 4: 4.4-fold (0.65 log units) above; the measured number lies below the stated range.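

In this assay, replacing 2,3-dihydro-1H-inden-2-yl with the group carrying the four-membered ring gives a 3.8-fold lower number from compound 2 to compound 4 (0.58 log units; beyond the scatter). Going by these compounds alone, this is the first readable comparison, and it shows that the value responds to the size of the non-aromatic ring at this place on the chain, with the aromatic ring and the chain kept. Nothing in the data shown accounts for this step.

As far as these compounds go, it remains open how a tetrahydronaphthalenyl group would read at this place. From the compounds shown here alone, it is also open whether the four-membered ring group would keep this value on a longer chain.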